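This account rests on a few compounds, and the source may have more. Where it says the series, first, only, none or still open, it means among the compounds named here.

Measured compounds in a functional assay on MCF7 cells (Homo sapiens) for inhibition, read by sulforhodamine B assay, with a stated time of 48 h; on this read-out lower numbers stand for stronger inhibition of growth and higher numbers for weaker inhibition of growth:
compound 1, `COc1ccc(/C=C/C2CC(=O)C=CO2)cc1OC`, gives 130 uM
compound 2, `COc1cc(/C=C/C2CC(=O)C=CO2)cc(OC)c1OC`, gives 149 uM
compound 3, `COc1ccc(C2CC(=O)C=CO2)cc1`, gives 173 uM

The three numbers sit close together. Among the compounds with values here, the one measured step, a 1.1-fold higher number from compound 1 to compound 2 (0.06 log units; within the scatter), is within the scatter. Within the data shown here, compound 3 has the largest of the three numbers, but its gaps to compound 2 and to compound 1 are also within the scatter, so no compound among the three can be set apart from the others.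

Compound 4, `COc1ccc(C2CC(=O)C(I)=CO2)cc1`, has not yet been measured. It differs from compound 3 in one place: iodo in place of hydrogen on a double-bonded ring carbon. The core is that of compound 3.

Among the measured compounds shown here, none of the measured steps bears on this change. For the measured compounds named here, the only step on record, a 1.1-fold higher number from compound 1 to compound 2 (0.06 log units; within the scatter), concerns a methoxy in place of hydrogen on an aromatic carbon, a different group at a different place, and it was within the scatter. The data therefore give no ground to expect a step beyond the scatter in either direction in this assay, and the expected step is a 1.4-fold lower number from compound 3 to compound 4 (0.16 log units; within the scatter).

On that basis compound 4 is estimated at 120 uM, with a range from 40 uM to 350 uM.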

Compound 4, concentration for growth inhibition (reported as GI): 43.2 uM
For compound 4 the middle estimate is 2.8-fold (0.44 log units) above the measured one; the range from low to high includes it.
By their numbers in this assay, from the lowest: compound 4; then compounds 1, 2 and 3 (each within the scatter of the next).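

In this assay, within the data shown here, iodo in place of hydrogen on a double-bonded ring carbon, two ring bonds from the ring oxygen, gives a 4.0-fold lower number from compound 3 to compound 4 (0.60 log units; beyond the scatter), the first step to lie beyond the scatter. The only earlier step, a 1.1-fold higher number from compound 1 to compound 2 (0.06 log units; within the scatter), placed a methoxy on an aromatic carbon and did not separate its two compounds, so this position of the six-membered non-aromatic ring is the first place shown where a single change moves the number by more than the scatter. Nothing in the available data explains the step.

Going by these compounds, it remains open whether this step belongs to iodo in particular or whether bromo, chloro, a methyl group or a nitrile at the same carbon would bring a similar one, since the whole finding rests on a single pair of compounds on the core of compound 3. On these data alone, it is also open whether iodo at this place would lower the number in the same way on the core of compound 1 or of compound 2.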